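The compounds below may be only part of what the source reports. "The series", "measured", "known", "first", "only" and "open" are said of these compounds alone.

Compound 3 `O=C(Nc1cccc(-c2nc3ccccc3s2)c1)c1ccnc(Cl)c1` belongs to a set of amides on a shared core, together with compound 1 `C/C=C/C(=O)Nc1cccc(-c2nc3ccccc3s2)c1` and compound 2 `O=C(Nc1cccc(-c2nc3ccccc3s2)c1)c1cnccc1Cl`. In an ADME assay on BJ cells (Homo sapiens) for inhibition, with a stated time of 72 h (on this read-out lower numbers stand for an effect already at smaller amounts and higher numbers for an effect only at larger amounts of compound), compound 3 gives only a limit, > 25000 nM. Compound 1 likewise reaches only the limit, > 25000 nM. Compound 2 also sits at the limit, > 25000 nM. The steps a step that the two limits leave unreadable from compound 1 to compound 2, a step that the two limits leave unreadable from compound 1 to compound 3 and a step that the two limits leave unreadable from compound 2 to compound 3 cannot be sized because of the limit of > 25000 nM in this assay, at which 3 of the 3 values shown sit. Compound 4 `O=C(Nc1cccc(-c2nc3ccccc3s2)c1)c1cnc(Cl)s1` differs from compound 3 by 2-chloro-1,3-thiazol-5-yl in place of 2-chloropyridin-4-yl on a carbonyl carbon. Among the compounds with values here, no measured step bears on this change with a readable size, as every comparison so far ends at the limit. Compound 4 is therefore expected to remain at the limit as well, with the step that the limit leaves unreadable from compound 3 to compound 4 expected to stay within the scatter. The estimate for compound 4 in this assay is 30000 nM, between 15000 nM and 100000 nM.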

Compound 4, half-maximal effective concentration: > 25000 nM
Compound 4 ended at the assay's limit (the forecaster's own chance of this, stated with the estimate: 85%); the middle value is on the limit's open side.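

No step can be read from compound 4 to compound 1, compound 2 or compound 3, because all four compounds end at the same limit: the limit of > 25000 nM in this assay, at which 4 of the 4 values shown sit.

The compounds shown leave open whether any amide on the shared core gives a measurable value in this assay.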